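Series notes: from nitro to the second amidine-type group

This account rests on a few compounds, and the source may have more. Where it says the series, first, only, none or still open, it means among the compounds named here.

For the measured compounds named here, compound 2 `CC1(c2ccc(-c3cccc([N+](=O)[O-])c3)cc2)CC(S(=O)(=O)c2ccc(F)cc2)=C(c2ccc(/C(N)=N\O)cc2)O1` holds the highest of the two numbers so far: in an ADME assay on J774.A1 cells (Mus musculus) for cytotoxicity, read by MTT assay, with a stated time of 72 h (on this read-out higher numbers stand for lower toxicity in this test and lower numbers for higher toxicity in this test), compound 2 gives 11100 nM, while compound 1 `CC1(c2ccc(-c3ccccc3C#N)cc2)CC(S(=O)(=O)c2ccc(F)cc2)=C(c2ccc(/C(N)=N\O)cc2)O1` gives 9290 nM, and the step of a 1.2-fold higher number from compound 1 to compound 2 (0.08 log units; within the scatter) stays within the scatter. Going by the values given here, compound 3 `CC1(c2ccc(-c3cccc(/C(N)=N\O)c3)cc2)CC(S(=O)(=O)c2ccc(F)cc2)=C(c2ccc(/C(N)=N\O)cc2)O1` carries the change (a group of 4 heavy atoms (1 carbon, 2 nitrogen, 1 oxygen; no ring) in place of a group of 3 heavy atoms (1 nitrogen, 2 oxygen; no ring), on an aromatic carbon), at the same aromatic carbon where the single measured step changed the substituent without effect beyond the scatter. No step beyond the scatter is therefore expected; for compound 3 the estimate in this assay is 11000 nM, between 4500 nM and 27000 nM, meaning an expected step of a 1.0-fold lower number from compound 2 to compound 3 (0.00 log units; within the scatter).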

Compound 3, half-maximal cytotoxic concentration: 11000 nM
Beside the measured number, compound 3's estimate shows no gap at the digits printed, within the range that was stated.
By their numbers in this assay, from the lowest: compounds 1, 3 and 2 (each within the scatter of the next).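

At this aromatic carbon, meta to a large group, a group with 2 hydrogen-bond donors replaces nitro with its 0, and this assay shows a 1.0-fold lower number from compound 2 to compound 3 (0.00 log units; within the scatter). The comparison with the 2-cyanophenyl substituent also stays flat, at a 1.2-fold higher number from compound 1 to compound 3 (0.07 log units; within the scatter), so this position has now tolerated three different groups with no step beyond the scatter. Nothing measured on these compounds bears on this result.

On these data alone, whether an amine or a carboxylic acid on this carbon would stay within the scatter remains open. The compounds shown also leave open whether changes elsewhere on the shared core would move the number.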